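Replacing the Sulfonyl Aryl Group of Compound 2

The source may hold more compounds than are shown below. What is called first, only, known or untested is meant among the compounds shown, and "the series" means these compounds.

Compound 2 `O=S(=O)(c1cccc(F)c1)c1cn(C2CCCNC2)c2ncccc12` holds the lowest of the two numbers in an assay on HeLa cells for displacement of a labelled ligand from 5-hydroxytryptamine receptor 6 (Homo sapiens) (on this read-out lower numbers stand for stronger inhibition and higher numbers for weaker inhibition), at 2.4 nM; compound 1 `O=S(=O)(c1ccc(Cl)cc1)c1cn(C2CCCNC2)c2ncccc12` gives 7.6 nM, and the two are separated by a 3.2-fold lower number from compound 1 to compound 2 (0.50 log units; beyond the scatter). Compound 3 `O=S(=O)(C1=C(Cl)NC2SC=CN12)c1cn(C2CCCNC2)c2ncccc12` differs from compound 2 by a group of 9 heavy atoms (5 carbon, 2 nitrogen, 1 sulfur, 1 chlorine; 2 five-membered non-aromatic rings with 2 hetero atoms each) in place of a group of 7 heavy atoms (6 carbon, 1 fluorine; one six-membered aromatic ring of carbon only), on a sulfonyl sulfur. Among the compounds with values here, the one measured step exchanged a single substituent on the same phenyl ring, so no measured step bears directly on the replacement of the whole group. A modest move towards weaker binding is expected, a 13-fold higher number from compound 2 to compound 3 (1.10 log units; beyond the scatter). Compound 3 is therefore estimated at 30 nM, within 5 nM to 200 nM.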

Compound 3, inhibition constant: 0.7 nM
The estimate for compound 3 lay 43-fold (1.63 log units) above the measured number; measured number outside the range, below it.
By their numbers in this assay, from the lowest: compound 3; then compound 2; then compound 1.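

On the sulfonyl sulfur, a phenyl ring need not be kept: in this assay, the group with 2 five-membered non-aromatic rings gives a 3.4-fold lower number from compound 2 to compound 3 (0.54 log units; beyond the scatter) and an 11-fold lower number from compound 1 to compound 3 (1.04 log units; beyond the scatter) on that exchange. The whole aryl group can thus be replaced without loss, by a group carrying 1 hydrogen-bond donor and 3 hydrogen-bond acceptors where the 3-fluorophenyl has none. Nothing available accounts for this gain. The compounds shown leave open what the chlorine of the entering group contributes, and how an amine or a methoxy group on the sulfonyl sulfur would compare.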